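A Chlorophenyl Amide Replaces a Methylsulfonyl Phenyl Amide

A few compounds are considered here, and "the series" means these few. Any claim that something is new, unique, unknown or untested is made for them only; others in the source may bear on it.

Of the compounds shown here, three built on one shared core have been tested in a functional assay on T47D cells (Homo sapiens) for antiproliferative activity, read by MTT assay, with a stated time of 72 h; on this read-out higher numbers stand for weaker inhibition and lower numbers for stronger inhibition. Compound 1 `O=C(Nc1ccc(Cl)c(-c2nnc3c(Cl)cccn23)c1)c1ccccn1` carries a pyridin-2-yl group on the amide carbonyl carbon. In this assay compound 1 gives only a limit of the assay, > 100000 nM. Compound 2 `O=C(Nc1ccc(Cl)c(-c2nnc3c(Cl)cccn23)c1)c1cccnc1` carries a pyridin-3-yl group in the same place. In this assay compound 2 likewise gives only a limit, > 100000 nM. Compound 3 `CS(=O)(=O)c1cccc(C(=O)Nc2ccc(Cl)c(-c3nnc4c(Cl)cccn34)c2)c1` carries a 3-(methylsulfonyl)phenyl group there. In this assay compound 3 again gives only a limit, > 100000 nM. Going by the values given here, compound 3 thus stands exactly where every value so far stands: the limit of > 100000 nM in this assay, at which 3 of the 3 values shown sit. None of the steps between these compounds can be read: a step that the two limits leave unreadable from compound 1 to compound 2, a step that the two limits leave unreadable from compound 1 to compound 3 and a step that the two limits leave unreadable from compound 2 to compound 3 all lie between two limits.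

Compound 4 `O=C(Nc1ccc(Cl)c(-c2nnc3c(Cl)cccn23)c1)c1ccccc1Cl` differs from compound 3 in one place: 2-chlorophenyl in place of 3-(methylsulfonyl)phenyl on a carbonyl carbon. Among the compounds with values here, no measured step bears on this change, since all three steps are unreadable, so no direction or size can be drawn from them. The step from compound 3 to compound 4 is expected to be a number no higher from compound 3 to compound 4 (the limit leaves the size open). Compound 4 is expected to give 100000 nM, with a range from 20000 nM to 300000 nM, and most likely the assay will again report only a limit.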

Compound 4, half-maximal inhibitory concentration: 83800 nM
For compound 4 the middle estimate is 1.2-fold (0.08 log units) above the measured one; low and high end bracket the measured number.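

With 2-chlorophenyl on the carbonyl carbon, compound 4 is the only compound shown that gives a number rather than a limit in this assay, so a change at this position can bring the read-out onto the measurable scale. Set against the groups it replaces, the change gives an at least 1.1-fold lower number from compound 3 to compound 4 (0.07 log units; that floor lies within the scatter), an at least 1.1-fold lower number from compound 2 to compound 4 (0.07 log units; that floor lies within the scatter) and an at least 1.1-fold lower number from compound 1 to compound 4 (0.07 log units; that floor lies within the scatter); each of these is only a floor, so the true size of each step stays open and no gain beyond the scatter is established. The steps among compounds 1, 2 and 3 still cannot be read, and limits still make up most of the data: the limit of > 100000 nM in this assay, at which 3 of the 4 values shown sit.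

The compounds shown leave open whether the chlorine matters at all, since a plain phenyl group on the same carbonyl carbon would be needed to separate the chlorine from the carbon-only ring that carries it. They also leave open whether other groups in this place, such as a fluorophenyl, a methoxyphenyl or an aminophenyl group, would give numbers clearly lower than that of compound 4.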